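Methyl branches on a fatty acid receptor agonist series

The source may report more compounds than this note shows. Statements on the series, on what has been measured and on what is new or still open speak of the compounds shown alone.

A small set of phenoxyacetamides bearing an acidic side chain was examined for agonist activity. Compound 1 `O=C(O)COc1ccc(NC(=O)COc2ccccc2)cc1F` gives 29.8% in a functional assay on CHO cells for agonist activity at Free fatty acid receptor 1 (Homo sapiens), read by FLIPR, tested at 100 nM; on this read-out lower numbers stand for a weaker effect and higher numbers for a stronger effect at the one concentration tested. Compound 2 `CC(Oc1ccccc1)C(=O)Nc1ccc(OCC(=O)O)c(F)c1` differs from it by methyl in place of hydrogen on a saturated chain carbon bound to a carbonyl carbon and an oxygen on an aromatic ring and, in this assay, compound 2 gives 35.7%; the step of a number 5.9 percentage points higher from compound 1 to compound 2 (within the scatter). Compound 3 `CC(C)c1cccc(OCC(=O)Nc2ccc(OCC(=O)O)c(F)c2)c1` differs from compound 1 by isopropyl in place of hydrogen on an aromatic carbon; in this assay compound 3 gives 43.3%, and the step of a number 13.5 percentage points higher from compound 1 to compound 3 (beyond the scatter). Compound 3 holds the highest number of the three, though its gap to compound 2 lies within the scatter.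

Compound 4 `CC(C)(C)c1cccc(OCC(=O)Nc2ccc(OCC(=O)O)c(F)c2)c1` has not been measured. It differs from compound 3 by methyl in place of hydrogen on a saturated chain carbon bound to an aromatic carbon and two saturated chain carbons. This is the same kind of change as that from compound 1 to compound 2, a methyl in place of hydrogen, but the surroundings differ: in the earlier case the saturated chain carbon is bound to a carbonyl carbon and an oxygen on an aromatic ring, whereas here it is bound to an aromatic carbon and two saturated chain carbons. Because the earlier step of a number 5.9 percentage points higher from compound 1 to compound 2 (within the scatter) stayed within the scatter, a step of comparable size is expected here, a number 2.7 percentage points higher from compound 3 to compound 4 (within the scatter). Compound 4 is therefore estimated at 46% in this assay, with a plausible range from 31% to 61%.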

Compound 4, a percentage reported as activity, at one concentration (the size of the read-out at that concentration, not a potency): 40.2%
Estimate against measurement, compound 4: 5.8 percentage points above; the measured number falls inside the stated range.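

In this assay, replacing hydrogen with methyl to turn isopropyl into tert-butyl gives a number 3.1 percentage points lower from compound 3 to compound 4 (within the scatter), while the whole tert-butyl group in place of hydrogen on an aromatic carbon gives a number 10.4 percentage points higher from compound 1 to compound 4 (beyond the scatter). Set beside the earlier methyl change, the new step does not differ from it, and neither step can be told from repeated measurement: the same change on two cores in this assay, a number 5.9 percentage points higher (within the scatter) from compound 1 to compound 2 and a number 3.1 percentage points lower (within the scatter) from compound 3 to compound 4, 9 percentage points apart, within the scatter of two such steps This shows that, in these two settings, methyl in place of hydrogen produced no readable change, but it does not establish a transferable effect of any fixed size or direction, as there are only two examples, at differently bound saturated chain carbons, each read at a single concentration.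

The compounds shown leave open whether the rise from compound 1 is specific to branched alkyl groups or would also appear with a trifluoromethyl, a methoxy or a chlorine on that aromatic carbon. They also leave open how a longer chain or an amine at the same place would behave, and whether the similar numbers for compound 3 and compound 4 would hold across a full concentration range.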